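The compounds below may be only part of what the source reports. "The series", "measured", "known", "first", "only" and "open" are said of these compounds alone.

Of the compounds shown here, three from the same series have been measured in a functional assay on A549 cells (Homo sapiens) for antiproliferative activity, read by MTT assay, with a stated time of 48 h; on this read-out higher numbers stand for weaker inhibition and lower numbers for stronger inhibition. Compound 1 `C/C(=C\CC/C(C)=C/CC[C@@H]1[C@@]2(C)CCC(=O)C(C)(C)[C@H]2CC[C@@]1(C)O)CC/C=C(\C)C(=O)OCc1cn(-c2cccc(O)c2)nn1` gives 42800 nM, compound 2 `C#CCOC(=O)/C(C)=C/CC/C(C)=C/CC/C(C)=C/CC[C@@H]1[C@@]2(C)CCC(=O)C(C)(C)[C@H]2CC[C@@]1(C)O` gives 45100 nM, and compound 3 `C/C(=C\CC/C(C)=C/CC[C@@H]1[C@@]2(C)CCC(=O)C(C)(C)[C@H]2CC[C@@]1(C)O)CC/C=C(\C)C(=O)OCc1cn(-c2cccc(Cl)c2)nn1` gives 147000 nM. Compound 2 therefore holds the second highest of the three numbers: its nearest neighbour is compound 1, with a step of a 1.1-fold higher number from compound 1 to compound 2 (0.02 log units; within the scatter), and its furthest is compound 3, with a step of a 3.3-fold higher number from compound 2 to compound 3 (0.51 log units; beyond the scatter). The step from compound 1 to compound 3, a 3.4-fold higher number from compound 1 to compound 3 (0.54 log units; beyond the scatter), sits at the aromatic carbon rather than at the chain.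

Compound 4 `C/C(=C\CC/C(C)=C/CC[C@@H]1[C@@]2(C)CCC(=O)C(C)(C)[C@H]2CC[C@@]1(C)O)CC/C=C(\C)C(=O)O` differs from compound 2 by hydrogen in place of propargyl on an oxygen next to a carbonyl group. Going by the values given here, no measured step removes the propargyl group outright; the two steps that touch the same oxygen next to a carbonyl group, a 1.1-fold higher number from compound 1 to compound 2 (0.02 log units; within the scatter) and a 3.3-fold higher number from compound 2 to compound 3 (0.51 log units; beyond the scatter), range from within the scatter to modest. For compound 4 a step of about a 1.2-fold higher number from compound 2 to compound 4 (0.09 log units; within the scatter) in this assay is therefore expected, close to no change. Compound 4 is estimated at 55000 nM, with a range from 20000 nM to 150000 nM.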

Compound 4, half-maximal inhibitory concentration: > 150000 nM
Compound 4 ended at the assay's limit; the forecaster's own chance of this, stated with the estimate: 15%; middle value at least 2.7-fold (0.43 log units) from the limit.
By their numbers in this assay, from the lowest: compounds 1 and 2 (each within the scatter of the next); then compound 3. At a limit, above all of these: compound 4.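

Compound 4 stands at a limit of this assay, which is not a number: the limit of > 150000 nM in this assay, at which 1 of the 4 values shown sits. On these data alone, with carboxy in place of propargyloxycarbonyl, the change reads as an at least 3.3-fold higher number from compound 2 to compound 4 (0.52 log units; beyond the scatter), so the group on this oxygen next to a carbonyl group does matter in this assay, and the true size of the step stays open on the upper side. Until now this oxygen had carried only a substituent, and compounds 1, 2 and 3 each gave a number; compound 4 shows that hydrogen at this place gives none within the range of the assay.

As far as these compounds go, how far compound 4 lies past its limit remains unknown. The compounds shown also leave open whether a simple methyl ester or an amide at this place would read like compound 1 and compound 2.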